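Aryl amide swap from compound 2 to compound 3

A few compounds are considered here, and "the series" means these few. Any claim that something is new, unique, unknown or untested is made for them only; others in the source may bear on it.

Among the measured compounds shown here, in a functional assay on SK-BR-3 cells (Homo sapiens) for antiproliferative activity, read by MTT assay, with a stated time of 72 h (on this read-out lower numbers stand for stronger inhibition and higher numbers for weaker inhibition), compound 1 (`CCN1CCN(c2cc(C)c3cc(NC(=O)c4ccccc4F)ccc3n2)CC1`) gives 38100 nM and compound 2 (`CCc1ccccc1C(=O)Nc1ccc2nc(N3CCN(CC)CC3)cc(C)c2c1`) gives 23900 nM with the two values inside the scatter of each other, so compound 2 holds no distinct place on the numbers so far. Compound 3 (`CCN1CCN(c2cc(C)c3cc(NC(=O)c4ccc(F)c(F)c4)ccc3n2)CC1`) carries 3,4-difluorophenyl in place of 2-ethylphenyl on a carbonyl carbon. For the measured compounds named here, the only measured step bearing on this is a 1.6-fold lower number from compound 1 to compound 2 (0.20 log units; within the scatter) for ethyl in place of fluoro on an aromatic carbon of the same group, and it lies within the scatter. Going by the values given here, with that single step as a guide, no change beyond the scatter is expected in this assay and no direction can be assigned, although the 3,4-difluorophenyl group has no measured precedent here. The expected step is small, a 1.2-fold higher number from compound 2 to compound 3 (0.07 log units; within the scatter) by this estimate. Compound 3 is estimated at 28000 nM with an expected range from 10000 nM to 70000 nM in this series.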

Compound 3, half-maximal inhibitory concentration: 1980 nM
Compound 3: the middle estimate sits 14-fold (1.15 log units) above what was measured; measured number outside the range, below it.
By their numbers in this assay, from the lowest: compound 3; then compounds 2 and 1 (each within the scatter of the next).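

In this assay the group on the carbonyl carbon emerges as a place where the number can move substantially: 3,4-difluorophenyl in place of 2-ethylphenyl gives a 12-fold lower number from compound 2 to compound 3 (1.08 log units; beyond the scatter), and in place of 2-fluorophenyl it gives a 19-fold lower number from compound 1 to compound 3 (1.28 log units; beyond the scatter). The earlier change from 2-fluorophenyl to 2-ethylphenyl, a 1.6-fold lower number from compound 1 to compound 2 (0.20 log units; within the scatter), stayed within the scatter, so this sensitivity becomes visible only with compound 3. Nothing measured here accounts for the size of these steps.

The compounds shown leave open whether a phenyl carrying a single fluorine would give the same gain or whether both fluorines are needed. Also open, from the compounds shown here alone, is how an unsubstituted phenyl, or a phenyl bearing chlorine or methoxy, would read at the same carbonyl carbon.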